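This account rests on a few compounds, and the source may have more. Where it says the series, first, only, none or still open, it means among the compounds named here.

Measured so far in an assay on isolated protein for inhibition of RAC-alpha serine/threonine-protein kinase (Homo sapiens); a higher number here means a weaker inhibitor, a lower number a stronger inhibitor:
compound 1 `Nc1ncnc(N2CC[C@@]3(CCCN(C[C@H](O)CNS(=O)(=O)c4ccccc4Br)C3)C2)c1C1CC1` gives 17 nM
compound 2 `Cc1cc(F)ccc1S(=O)(=O)NC[C@@H](O)CN1CCC[C@@]2(CCN(c3ncnc(N)c3C3CC3)C2)C1` gives 8 nM

Compound 2 stands at the lowest of the two numbers in this assay; its nearest neighbour is compound 1, and the step of a 2.1-fold lower number from compound 1 to compound 2 (0.33 log units; beyond the scatter) came with 4-fluoro-2-methylphenyl in place of 2-bromophenyl on the sulfonyl sulfur.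

Compound 3 `Cc1ccc(S(=O)(=O)NC[C@@H](O)CN2CCC[C@@]3(CCN(c4ncnc(N)c4C4CC4)C3)C2)c(C)c1` has not yet been measured. It differs from compound 2 by methyl in place of fluoro on an aromatic carbon. Among the measured compounds shown here, no measured step exchanges fluoro for methyl on its own; the only measured step, from compound 1 to compound 2, swapped the whole aryl group and so does not isolate this exchange. With nothing pointing one way, the expectation in this assay is a step of about no change at the digits printed from compound 2 to compound 3 (within the scatter), not beyond the scatter. For compound 3 the estimated value is 8 nM, expected to lie between 4 nM and 16 nM.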

Compound 3, half-maximal inhibitory concentration: 160 nM
For compound 3 the middle estimate is 20-fold (1.30 log units) below the measured one; the measured number lies above the stated range.
By their numbers in this assay, from the lowest: compound 2; then compound 1; then compound 3.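

In this assay, exchanging fluoro for methyl on an aromatic carbon para to a large group gives a 20-fold higher number from compound 2 to compound 3 (1.30 log units; beyond the scatter), so this carbon tolerates no free swap, even though the exchange keeps the heavy-atom count unchanged. The wider aryl comparison gives a 9.4-fold higher number from compound 1 to compound 3 (0.97 log units; beyond the scatter), so 2,4-dimethylphenyl falls behind 2-bromophenyl, whereas 4-fluoro-2-methylphenyl gave a 2.1-fold lower number from compound 1 to compound 2 (0.33 log units; beyond the scatter) and the direction of an aryl swap now depends on the group at this carbon. No supporting measurement accounts for the size of this change.

Still open, on these data alone, is whether the loss is specific to methyl or extends to other replacements of fluoro, such as hydrogen, chloro, methoxy or an amine at this carbon. Equally open, as far as these compounds go, is whether the same sensitivity holds when the neighbouring methyl group is replaced by chloro or ethyl.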